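Inverting a Ring Stereocentre in a Cytotoxic Peroxide

A few compounds are considered here, and "the series" means these few. Any claim that something is new, unique, unknown or untested is made for them only; others in the source may bear on it.

Going by the values given here, compound 1 `CC(CC/C=C/CC/C=C/c1ccccc1)C[C@]1(C)C[C@@](C)(CC(=O)O)OO1` gives 0.026 ug/mL in a functional assay on L1210 cells (Mus musculus) for cytotoxicity (on this read-out lower numbers stand for stronger inhibition and higher numbers for weaker inhibition), the second highest of the three numbers measured so far. Its nearest neighbour is compound 2 `COC(=O)C[C@]1(C)C[C@@](C)(CC(C)CC/C=C/CC/C=C/c2ccccc2)OO1`, which in this assay gives 0.0043 ug/mL; the furthest is compound 3 `COC(=O)C[C@@]1(C)C[C@@](C)(CC(C)CCCC/C=C/CC/C=C\c2ccccc2)OO1`, which in this assay gives 0.29 ug/mL. Among the compounds with values here, the only measured step, a 6.0-fold lower number from compound 1 to compound 2 (0.78 log units; beyond the scatter), concerns a different part of the molecule. Compound 4 `CC(CC/C=C/CC/C=C/c1ccccc1)C[C@@]1(C)C[C@@](C)(CC(=O)O)OO1` differs from compound 1 in one respect only: the two compounds have the same atoms and bonds; at least one stereo element is drawn with a configuration in one of them and without one in the other: 1 of 5 stereo elements differ; a stereocentre at a saturated ring carbon is drawn R in compound 1 and S in compound 4. Within the data shown here, no measured step addresses such a change, so nothing in these data argues for a shift beyond the scatter. The expected step is therefore a 1.5-fold higher number from compound 1 to compound 4 (0.19 log units; within the scatter), essentially none. Compound 4 is estimated at 0.04 ug/mL in this assay, with a range from 0.01 ug/mL to 0.16 ug/mL.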

Compound 4, half-maximal inhibitory concentration: 0.017 ug/mL
For compound 4 the middle estimate is 2.4-fold (0.37 log units) above the measured one; low and high end bracket the measured number.
By their numbers in this assay, from the lowest: compound 2; then compounds 4 and 1 (each within the scatter of the next); then compound 3.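

Inverting the stereocentre at the saturated ring carbon from R to S brings a 1.5-fold lower number from compound 1 to compound 4 (0.18 log units; within the scatter) in this assay. The earlier step concerned a methyl in place of hydrogen on an oxygen, whereas this one shows that the configuration at this ring carbon, in the free acid, moves the number no further than the scatter. The reading carries one caveat: the fact that one of compounds 1 and 4 is drawn with a defined configuration and the other without, at the place where they differ. From the compounds shown here alone, whether the same holds with an ethyl ester or an amide in place of the carboxylic acid stays open.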